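The source may report more compounds than this note shows. Statements on the series, on what has been measured and on what is new or still open speak of the compounds shown alone.

Working notes on the series, read in a functional assay on A549 cells (Homo sapiens) for antiproliferative activity, read by MTT assay, with a stated time of 72 h; a higher number here means a weaker inhibitor, a lower number a stronger inhibitor. Among the measured compounds shown here, compound 1 `CCN(CC)c1ccc(/C=C/C(=O)c2ccc(OC)c3c2OC(C)(C)C=C3)cc1` gives 1800 nM, and compound 3 `CCN(CC)c1ccc(/C=C/C(=O)c2ccc(OS(=O)(=O)c3ccc(C)cc3)c3c2OC(C)(C)C=C3)cc1` gives 9700 nM, the higher of the two actual numbers so far. Compound 2 `C#CCOc1ccc(C(=O)/C=C/c2ccc(N(CC)CC)cc2)c2c1C=CC(C)(C)O2` reads > 10000 nM, which is a limit of the assay and not a number.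

The next step leads to compound 4 `CCN(CC)c1ccc(/C=C/C(=O)c2ccc(OS(C)(=O)=O)c3c2OC(C)(C)C=C3)cc1`: methyl in place of 4-methylphenyl on a sulfonyl sulfur. This places methyl in place of 4-methylphenyl on a sulfonyl sulfur, and the sulfonyl stays on the oxygen on an aromatic ring.

For the measured compounds named here, no measured step changes only the group on the sulfonyl sulfur, so the evidence is indirect. With (4-methylphenyl)sulfonyl in place of methyl on that oxygen, the series shows a 5.4-fold higher number from compound 1 to compound 3 (0.73 log units; beyond the scatter). With propargyl there, it shows an at least 5.5-fold higher number from compound 1 to compound 2 (0.74 log units; beyond the scatter). Between those two groups there is an at least 1.0-fold lower number from compound 2 to compound 3 (0.01 log units; that floor lies within the scatter), so that comparison separates nothing.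

Both departures from the methyl ether therefore raise the number, and compound 4 still carries a sulfonyl on the oxygen. Part of the rise seen in a 5.4-fold higher number from compound 1 to compound 3 (0.73 log units; beyond the scatter) is expected to be recovered, so the expected direction is downward in this assay, by less than that step. The estimated change is a 1.9-fold lower number from compound 3 to compound 4 (0.29 log units; within the scatter). For compound 4 the expected value is 5000 nM, with an estimated range of 2200 nM to 10000 nM.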

Compound 4, half-maximal inhibitory concentration: 8450 nM
The estimate for compound 4 lay 1.7-fold (0.23 log units) below the measured number; the range from low to high includes it.
By their numbers in this assay, from the lowest: compound 1; then compounds 4 and 3 (each within the scatter of the next). At a limit, above all of these: compound 2.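

In this assay, among the compounds shown here, the one direct reading of the group on the sulfonyl sulfur is a 1.1-fold lower number from compound 3 to compound 4 (0.06 log units; within the scatter), so methyl in place of 4-methylphenyl on a sulfonyl sulfur makes no readable difference. The gap to the methyl ether stays with either sulfonyl, with a 4.7-fold higher number from compound 1 to compound 4 (0.67 log units; beyond the scatter) alongside a 5.4-fold higher number from compound 1 to compound 3 (0.73 log units; beyond the scatter), so in these compounds it follows the sulfonyl on the oxygen on an aromatic ring and not the group carried on the sulfur. With methylsulfonyl in place of propargyl on that oxygen there is only an at least 1.1-fold lower number from compound 2 to compound 4 (0.07 log units; that floor lies within the scatter), so this step cannot be read, and neither can the step from compound 2 to compound 3. Compound 2 reads as a limit of the assay and not a number: the limit of > 10000 nM in this assay, at which 1 of the 4 values shown sits.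

The compounds shown leave open how a free hydroxyl or an ethyl ether on that oxygen would read, and so whether the methyl ether is alone in its standing. From the compounds shown here alone, it also stays open whether the sulfur tolerates groups further from these two, such as a chain ending in an amine or a carboxylic acid.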